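Swapping the Aryl Group on the Amide-Type Nitrogen

The source may hold more compounds than are shown below. What is called first, only, known or untested is meant among the compounds shown, and "the series" means these compounds.

Compound 1, `Fc1cccc(NC(=S)N/N=C/c2ccc3ccccc3n2)c1`, gives 79900 nM in a functional assay on SGC-7901 cells (Homo sapiens) for antiproliferative activity, read by sulforhodamine B assay, with a stated time of 72 h; a lower number here means a stronger inhibitor, a higher number a weaker inhibitor.
Compound 2, `Fc1ccccc1NC(=S)N/N=C/c1ccc2ccccc2n1`, reaches only a limit of that assay, > 100000 nM.
Compound 3, `S=C(N/N=C/c1ccc2ccccc2n1)Nc1ccc(Cl)cc1`, gives 87600 nM.

Compound 3 and compound 1 sit within the scatter of each other, as a 1.1-fold higher number from compound 1 to compound 3 (0.04 log units; within the scatter) shows. Against compound 2 the comparison rests on a limit, (the limit of > 100000 nM in this assay, at which 1 of the 3 values shown sits), and an at least 1.1-fold lower number from compound 2 to compound 3 (0.05 log units; that floor lies within the scatter) gives only a floor that lies within the scatter.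

The step from compound 3 to compound 4, `COc1ccccc1NC(=S)N/N=C/c1ccc2ccccc2n1`, is 2-methoxyphenyl in place of 4-chlorophenyl on an amide-type nitrogen. The two measured steps that bear on it, a 1.1-fold higher number from compound 1 to compound 3 (0.04 log units; within the scatter) and an at least 1.1-fold lower number from compound 2 to compound 3 (0.05 log units; that floor lies within the scatter), each swap the aryl group on the same amide-type nitrogen, and neither moves beyond the scatter; an at least 1.2-fold higher number from compound 1 to compound 2 (0.09 log units; that floor lies within the scatter) likewise gives only a floor within the scatter. So no step beyond the scatter is expected here in either direction.

Compound 4 is therefore estimated at 90000 nM, between 40000 nM and 150000 nM, an expected step of a 1.0-fold higher number from compound 3 to compound 4 (0.01 log units; within the scatter).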

Compound 4, half-maximal inhibitory concentration: > 100000 nM
Compound 4 gave a limit, no number; the forecaster's own chance of this, stated with the estimate: 40%; middle value at least 1.1-fold (0.04 log units) from the limit.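

Compound 4 joins compound 2 at the same limit of this assay, so 2-methoxyphenyl and 2-fluorophenyl both end at a limit while 3-fluorophenyl and 4-chlorophenyl give numbers: the limit of > 100000 nM in this assay, at which 2 of the 4 values shown sit. Even so, the readable steps, an at least 1.1-fold higher number from compound 3 to compound 4 (0.05 log units; that floor lies within the scatter) and an at least 1.2-fold higher number from compound 1 to compound 4 (0.09 log units; that floor lies within the scatter), give only floors, so this split is not a difference beyond the scatter, and swapping the aryl group on this amide-type nitrogen has still shown no step beyond it. The step between the two compounds at the limit cannot be read, which leaves methoxy and fluoro on the aromatic carbon unranked.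

From the compounds shown here alone, it remains open whether a phenyl ring bearing an amine or a carboxylic acid, or a longer alkyl chain in place of the aryl group, would give a number clear of these values. Going by these compounds, whether changes to the shared core matter more than this aryl group also stays open.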